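Extending an alkenyl chain on a thiadiazole glycoside

The compounds below may be only part of what the source reports. "The series", "measured", "known", "first", "only" and "open" are said of these compounds alone.

Measured compounds:
compound 1 `CCCCCCCC(=O)Nc1nnc(S[C@@H]2O[C@H](CO)[C@H](O)[C@H](O)[C@H]2O)s1`: 50800 nM
compound 2 `CCCCCCCCCCCC(=O)Nc1nnc(S[C@@H]2O[C@H](COC(C)=O)[C@H](OC(C)=O)[C@H](OC(C)=O)[C@H]2OC(C)=O)s1`: 51900 nM
compound 3 `C=CCCCCCCCCC(=O)Nc1nnc(S[C@@H]2O[C@H](CO)[C@H](O)[C@H](O)[C@H]2O)s1`: 58300 nM

In a functional assay on HeLa cells (Homo sapiens) for cytotoxicity, read by MTT assay, with a stated time of 24 h (on this read-out lower numbers stand for stronger inhibition and higher numbers for weaker inhibition), compound 3 gives 58300 nM, and this number sits within the scatter of the other two: compound 2 gives 51900 nM and compound 1 gives 50800 nM. The three measured compounds are thus indistinguishable on this read-out.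

Compound 4 `CCCCCCCC/C=C\CCCCCCCC(=O)Nc1nnc(S[C@@H]2O[C@H](CO)[C@H](O)[C@H](O)[C@H]2O)s1` has not yet been measured. It differs from compound 3 by dec-1-en-1-yl in place of allyl on a saturated chain carbon, seven bonds along the chain from a carbonyl carbon. Among the compounds with values here, the only measured step that touches the same place is a 1.1-fold higher number from compound 1 to compound 3 (0.06 log units; within the scatter), where adding the allyl group left the number within the scatter. Lengthening the chain further, as in compound 4, is a larger change of the same kind, yet the record from compound 1 to compound 3 gives no sign that the chain length at this position moves the read-out in this assay, and compound 2, with a different chain and acetylated sugar, gives the same kind of number.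

For compound 4 in this assay the step of a 1.1-fold lower number from compound 3 to compound 4 (0.03 log units; within the scatter) is therefore expected to stay within the scatter. The value for compound 4 is estimated at 55000 nM, with a range from 28000 nM to 110000 nM.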

Compound 4, half-maximal inhibitory concentration: 8800 nM
Beside the measured number, compound 4's estimate is 6.3-fold (0.80 log units) above it; measured number below the stated range.
By their numbers in this assay, from the lowest: compound 4; then compounds 1, 2 and 3 (each within the scatter of the next).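

In this assay this position, on a saturated chain carbon seven bonds along the chain from a carbonyl carbon, proves able to move the number: dec-1-en-1-yl in place of allyl gives a 6.6-fold lower number from compound 3 to compound 4 (0.82 log units; beyond the scatter) and dec-1-en-1-yl in place of hydrogen gives a 5.8-fold lower number from compound 1 to compound 4 (0.76 log units; beyond the scatter) and both steps lie beyond the scatter. Allyl in place of hydrogen, by contrast, gave a 1.1-fold higher number from compound 1 to compound 3 (0.06 log units; within the scatter) and stayed within it, so among these compounds only the dec-1-en-1-yl group shifts the read-out at this place. Allyl and dec-1-en-1-yl each carry one double bond and no ring, and of what is counted they differ only in carbon, with dec-1-en-1-yl carrying more. Nothing available explains the lower number of compound 4.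

Open, on these data alone, is where between allyl and dec-1-en-1-yl the change sets in, and whether a longer chain would go further or a fully saturated chain of the same length would do the same. Also open, as far as these compounds go, is how a terminal amine or carboxylic acid on the chain, or acetyl groups on the sugar of compound 4, would read in this assay.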